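A few compounds are considered here, and "the series" means these few. Any claim that something is new, unique, unknown or untested is made for them only; others in the source may bear on it.

In an assay for inhibition of protein deacetylase HDAC6 (Homo sapiens) (on this read-out higher numbers stand for weaker inhibition and lower numbers for stronger inhibition), compound 2 `NS(=O)(=O)NCCCC[C@H](NC(=O)OCc1ccccc1)c1n[nH]c(-c2ccccc2)n1` gives 320 nM, the lower of the two numbers shown, while compound 1 `N[C@@H](CCCCNS(N)(=O)=O)C(=O)Nc1nc(-c2ccccc2)cs1` gives 1100 nM, a gap that lies beyond the scatter. Compound 3 `Cn1nc([C@H](CCCCNS(N)(=O)=O)NC(=O)OCc2ccccc2)nc1-c1ccccc1` is not yet measured; it differs from compound 2 by methyl in place of hydrogen on an aromatic nitrogen. Within the data shown here, no measured pair shows a change of this kind, so the expected step is a 1.3-fold higher number from compound 2 to compound 3 (0.10 log units; within the scatter), a size within the scatter and in no firm direction. Compound 3 is therefore expected to give 400 nM in this assay, with a range from 150 nM to 1200 nM.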

Compound 3, half-maximal inhibitory concentration: 2000 nM
Estimate against measurement, compound 3: 5.0-fold (0.70 log units) below, and the stated range ends below it.
By their numbers in this assay, from the lowest: compound 2; then compounds 1 and 3 (each within the scatter of the next).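

In this assay, methyl in place of hydrogen on an aromatic nitrogen, next to the ring atom that bears a phenyl group, gives a 6.3-fold higher number from compound 2 to compound 3 (0.80 log units; beyond the scatter), so inhibition at this position does not tolerate this change without a loss beyond the scatter. Among these compounds, this is the only step read at this position, so it speaks for methyl alone. No available evidence accounts for the size of this step. The compounds shown leave open whether an ethyl group on this nitrogen would give a larger or smaller step, and what methyl on another nitrogen of the ring would give.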